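This account rests on a few compounds, and the source may have more. Where it says the series, first, only, none or still open, it means among the compounds named here.

Measured compounds:
Compound 1 `O=C(/C=C/c1cc2ccccc2nc1Cl)c1ccc(Br)cc1` — "not determined" (no result reported)
Compound 2 `Cc1ccc2nc(Cl)c(/C=C/C(=O)c3cccc(Br)c3)cc2c1` — > 100000 nM
Compound 3 `C/C(=C\c1cc2cc(C)ccc2nc1Cl)C(=O)c1cccc(Br)c1` — "not determined" (no result reported)

In an ADME assay on MCF7 cells (Homo sapiens) for cytotoxicity, read by MTT assay, with a stated time of 48 h (on this read-out higher numbers stand for weaker inhibition and lower numbers for stronger inhibition), compound 1 has no single number; its entry reads "not determined" (no result reported). For compound 2 the result is a limit of the assay, > 100000 nM, and not a measured number. Compound 3 likewise stands without a number, as "not determined" (no result reported). Among the three values shown, one sits at the limit of > 100000 nM in this assay, at which 1 of the 3 values shown sits, so compound 1 cannot be placed against any measured figure, and no step between measured compounds exists here.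

Compound 4 `O=C(/C=C/c1cc2ccccc2nc1Cl)c1ccc(Cl)cc1` differs from compound 1 by chloro in place of bromo on an aromatic carbon. Since no number is known for compound 1, the size of this step cannot be read from the data, and any change is expected to stay within the usual scatter or remain unresolved at the limit. In this assay compound 4 is estimated at 80000 nM, with a range from 15000 nM to 300000 nM, because compound 2 gives > 100000 nM.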

Compound 4, half-maximal inhibitory concentration: > 100000 nM
Compound 4: no number, only a limit; the forecaster's own chance of this, stated with the estimate: 55%; middle value at least 1.2-fold (0.09 log units) from the limit.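

Compound 4 gives > 100000 nM in this assay, which is a limit of the assay and not a number. Among the compounds shown here, compound 1 has no single number either, so no step between compound 1 and compound 4 can be read. The compounds shown leave open whether exchanging 4-bromophenyl for 4-chlorophenyl changes the result in this assay.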